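A few compounds are considered here, and "the series" means these few. Any claim that something is new, unique, unknown or untested is made for them only; others in the source may bear on it.

Compound 1 `CC(C)(C)[C@@H](N)C(=O)NCc1ccc(Cl)cc1` gives 30 mg/kg in a functional assay on the whole organism (strain albino Sprague-Dawley) with Rattus norvegicus as the target, in the maximal electroshock model; a lower number here means that less compound is needed, a higher number that more compound is needed for the effect. Compound 2 `CC(C)(C)[C@@H](N)C(=O)NCc1ccc(C(F)(F)F)cc1` reaches only < 30 mg/kg in this assay, which is a limit of the assay and not a number. The step of a number no higher from compound 1 to compound 2 (the limit leaves the size open) therefore has no readable size, as the limit of < 30 mg/kg in this assay, at which 1 of the 2 values shown sits, shows. Compound 3 `CC(C)(C)[C@@H](N)C(=O)NCc1ccccc1` differs from compound 2 by hydrogen in place of trifluoromethyl on an aromatic carbon. Going by the values given here, no measured step covers this change; the single known step sets only a bound and carries no direction of its own. Compound 3 is expected to need a dose of about 70 mg/kg, with a range from 25 mg/kg to 200 mg/kg. The expected step of an at least 2.3-fold higher number from compound 2 to compound 3 (0.36 log units; beyond the scatter) is estimated to run toward a higher dose, beyond the usual scatter.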

Compound 3, dose for half-maximal effect: 11 mg/kg
Compound 3: the middle estimate sits 6.4-fold (0.80 log units) above what was measured, and the stated range ends above it.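

Going by these compounds alone, the first readable step at this position replaces chloro with hydrogen on the aromatic carbon. In this assay this change gives a 2.7-fold lower number from compound 1 to compound 3 (0.44 log units; beyond the scatter), so the effect does not depend on a substituent at this place, and hydrogen needs the lower dose of the two. The step involving trifluoromethyl cannot be read, as the value of compound 2 is a limit and not a number: the limit of < 30 mg/kg in this assay, at which 1 of the 3 values shown sits.

As far as these compounds go, it remains open where trifluoromethyl stands relative to hydrogen, and whether a methoxy group, a nitrile or an amine at this place would need a lower dose than hydrogen.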